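The source may hold more compounds than are shown below. What is called first, only, known or untested is meant among the compounds shown, and "the series" means these compounds.

The series shares a core in which a benzoyl group sits on a double-bonded chain, with an aryl or cycloalkyl group on the other double-bonded carbon and a one-carbon substituent at the first. Compound 1 `O=C(/C(=C/c1ccc(Cl)cc1Cl)CCl)c1ccccc1` carries a chloromethyl group and a dichlorophenyl ring, compound 2 `CC(=O)OC/C(=C\C1CCCCC1)C(=O)c1ccccc1` an acetoxymethyl group and a cyclohexyl ring, and compound 3 `CC(=O)OC/C(=C\c1ccc(Cl)cc1)C(=O)c1ccccc1` an acetoxymethyl group and a 4-chlorophenyl ring. In a functional assay on WiDr cells (Homo sapiens) for inhibition, read by sulforhodamine B assay, with a stated time of 48 h (a lower number here means a stronger inhibitor of growth, a higher number a weaker inhibitor of growth), compound 1 gives 13000 nM, compound 2 gives 21000 nM and compound 3 gives 4800 nM, so compound 3 holds the lowest of the three numbers, with compound 1 nearer to it and compound 2 furthest away. Among the compounds with values here, the one step between neighbours, a 4.4-fold lower number from compound 2 to compound 3 (0.64 log units; beyond the scatter), comes from putting a 4-chlorophenyl group in place of cyclohexyl on the double-bonded chain carbon.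

Compound 4 `CC(=O)OC/C(=C\c1ccc(Cl)cc1Cl)C(=O)c1ccccc1` follows compound 3 by a single change: chloro in place of hydrogen on an aromatic carbon. Within the data shown here, no measured step in this set concerns a chloro entering an aromatic ring, and compound 1, which carries the same dichlorophenyl ring, differs from compound 4 in the one-carbon substituent as well, so its value in this assay bears only loosely on the question. The step from compound 3 to compound 4 is therefore expected to stay within the scatter, a 1.1-fold higher number from compound 3 to compound 4 (0.06 log units; within the scatter). Compound 4 is expected to give about 5500 nM in this assay, within a range from 2000 nM to 15000 nM.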

Compound 4, concentration for 50% growth inhibition: 14000 nM
Compound 4: middle estimate off by 2.5-fold (0.41 log units), on the low side; low and high end bracket the measured number.
By their numbers in this assay, from the lowest: compound 3; then compounds 1, 4 and 2 (each within the scatter of the next).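

In this assay chloro in place of hydrogen on this aromatic carbon, ortho to a large group and meta to the chloro group already present, gives a 2.9-fold higher number from compound 3 to compound 4 (0.46 log units; beyond the scatter) and so reverses part of the gain of a 4.4-fold lower number from compound 2 to compound 3 (0.64 log units; beyond the scatter) rather than extending it. With the dichlorophenyl ring in place, the choice of one-carbon substituent shows no readable effect: acetoxy in place of chloro on the saturated chain carbon gives a 1.1-fold higher number from compound 1 to compound 4 (0.03 log units; within the scatter) and that step stays within the scatter. Nothing among the available data explains why the number rises when this chloro enters.

The compounds shown do not tell whether a fluoro or a methoxy group on the same aromatic carbon would raise the number as chloro does, or whether the rise is specific to chloro. They also leave open whether acetoxy and chloro would still match on the 4-chlorophenyl ring of compound 3, and whether an amine or a hydroxyl group on the saturated chain carbon would match them.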